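Opening an Epoxide on a Bicyclic Enone Core

The compounds below may be only part of what the source reports. "The series", "measured", "known", "first", "only" and "open" are said of these compounds alone.

Measured so far:
- Compound 1, `C[C@@H]1CC(=O)C=C2CC[C@@H]([C@@]3(C)CO3)C[C@]21C`: 167 ug/mL
- Compound 2, `C=C(C)[C@@H]1C[C@@H](O)C2=CC(=O)C[C@@H](C)[C@]2(C)C1`: 62.7 ug/mL

Of the compounds shown here, two have been tested in a functional assay on A549 cells (Homo sapiens) for antiproliferative activity; on this read-out lower numbers stand for stronger inhibition and higher numbers for weaker inhibition. Compound 1 gives 167 ug/mL, the higher of the two numbers, and so the weaker inhibition. Compound 2 gives 62.7 ug/mL, and the gap between the two lies beyond the usual scatter of this assay, so compound 2 inhibits growth more strongly than compound 1 on the numbers at hand. No pair of these compounds differs in only one place, so no measured single step is available.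

Compound 3, `C=C(CO)[C@@H]1CCC2=CC(=O)C[C@@H](C)[C@]2(C)C1`, has not yet been measured. It keeps every atom of compound 1 but joins them differently: 1-(hydroxymethyl)ethenyl in place of 2-methyloxiran-2-yl on a saturated ring carbon. The group that leaves carries a small ring with an oxygen in it; the group that enters is open, with a hydroxyl that can donate a hydrogen bond.

Among the compounds with values here, with no measured step of this kind to lean on, only a modest change is expected, a step of a 1.4-fold lower number from compound 1 to compound 3 (0.14 log units; within the scatter) that may stay near the scatter. Compound 3 is estimated at 120 ug/mL, within a range from 45 ug/mL to 320 ug/mL.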

Compound 3, concentration for 50% inhibition: 36 ug/mL
For compound 3 the middle estimate is 3.3-fold (0.52 log units) above the measured one; measured number outside the range, below it.
By their numbers in this assay, from the lowest: compounds 3 and 2 (each within the scatter of the next); then compound 1.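

In this assay the change from 2-methyloxiran-2-yl to 1-(hydroxymethyl)ethenyl on the saturated ring carbon gives a 4.6-fold lower number from compound 1 to compound 3 (0.67 log units; beyond the scatter) and is the first measured single step among these compounds. It shows that this position is not indifferent to what it carries: the two groups hold the same atoms, joined either as a closed three-membered ring or as an open group with a double bond and a hydroxyl, yet they give clearly different numbers on the same core. No measurement at hand explains the difference, so the step stands as an observation only.

As far as these compounds go, this one step cannot separate the parts of the change, so it remains open whether opening the ring, the double bond or the hydroxyl accounts for the lower number. It also leaves open how the same ring carbon would respond to a quite different group, such as an amine, a carboxylic acid or a longer carbon chain ending in a hydroxyl.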